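This account rests on a few compounds, and the source may have more. Where it says the series, first, only, none or still open, it means among the compounds named here.

Measured in a functional assay on HL-60 cells (Homo sapiens) for inhibition, read by trypan blue exclusion, with a stated time of 72 h; on this read-out higher numbers stand for weaker inhibition of growth and lower numbers for stronger inhibition of growth:
compound 1, `C=C(CC)C(=O)c1ccc(OCc2nc(-c3ccc([N+](=O)[O-])cc3)cs2)cc1Cl`, gives 800 nM.
compound 2, `C=C(CC)C(=O)c1ccc(OCc2nc(-c3ccc4ccccc4c3)cs2)cc1Cl`, gives 900 nM.

Among the measured compounds shown here, compound 2 carries the higher of the two numbers in this assay; its only neighbour is compound 1, and the step of a 1.1-fold higher number from compound 1 to compound 2 (0.05 log units; within the scatter) lies within the scatter, so the two compounds are not separable on these data.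

Compound 3, `C=C(C)C(=O)c1ccc(OCc2nc(-c3ccc4ccccc4c3)cs2)cc1Cl`, is not yet measured. It differs from compound 2 by hydrogen in place of methyl on a saturated chain carbon bound to a double-bonded chain carbon; cut one bond further out, the change reads ethyl to methyl. For the measured compounds named here, the single measured step, a 1.1-fold higher number from compound 1 to compound 2 (0.05 log units; within the scatter), concerns the aryl group on an aromatic carbon and does not touch this chain position, so no measured step bears on the change. With nothing to anchor it, the expected step of no change at the digits printed from compound 2 to compound 3 (within the scatter) is none beyond the scatter, and the range is set wide to reflect that. Compound 3 is therefore estimated at 900 nM, between 300 nM and 2700 nM.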

Compound 3, concentration for 50% growth inhibition: 2900 nM
Compound 3: the middle estimate sits 3.2-fold (0.51 log units) below what was measured, and the stated range ends below it.
By their numbers in this assay, from the lowest: compounds 1 and 2 (each within the scatter of the next); then compound 3.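

In this assay, the saturated chain carbon bound to a double-bonded chain carbon responds to a small change: ethyl to methyl, the loss of one carbon, gives a 3.2-fold higher number from compound 2 to compound 3 (0.51 log units; beyond the scatter), towards weaker inhibition of growth. Among the compounds shown here, this is the first single change to move the number beyond the scatter, whereas the aryl exchange gave only a 1.1-fold higher number from compound 1 to compound 2 (0.05 log units; within the scatter). Nothing available accounts for the size of this step.

The compounds shown leave open whether a longer chain at this place, such as propyl or butyl, would keep, improve or lower growth inhibition relative to the ethyl of compound 2. Also open, on these data alone, are whether a polar replacement such as a hydroxymethyl or aminomethyl group would be tolerated and whether the same step appears with 4-nitrophenyl in place of naphthalen-2-yl.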